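The source may report more compounds than this note shows. Statements on the series, on what has been measured and on what is new or still open speak of the compounds shown alone.

Measured in an ADME assay on Vero cells (Chlorocebus sabaeus) for cytotoxicity, read by MTT assay, with a stated time of 48 h; on this read-out lower numbers stand for higher toxicity in this test and higher numbers for lower toxicity in this test:

Compound 1 `O=C(CN1CCCC1)Nc1ncc([N+](=O)[O-])s1`: > 1000000 nM, a limit of the assay.
Compound 2 `CCN(CC)CC(=O)Nc1ncc([N+](=O)[O-])s1`: > 1000000 nM, a limit of the assay.
Compound 3 `CCN(CC)CC(=O)Nc1nc2ccc([N+](=O)[O-])cc2s1`: > 1000000 nM, a limit of the assay.

None of the three measured compounds gives a number in this assay; each reading is a limit of the assay, and all three sit at the limit of > 1000000 nM in this assay, at which 3 of the 3 values shown sit. For the measured compounds named here, the one structural change that can be followed between measured compounds is that from compound 2 to compound 1, in which (pyrrolidin-1-yl in place of diethylamino on a saturated chain carbon bound to a carbonyl carbon). Its step, a step that the two limits leave unreadable from compound 2 to compound 1, cannot be read in size, since both ends are limits. Compound 3 carries a different core from compound 2, and how the two cores differ is not broken down here.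

Compound 4 `O=C(CN1CCCC1)Nc1nc2ccc([N+](=O)[O-])cc2s1` is not yet measured. It differs from compound 3 in that (pyrrolidin-1-yl in place of diethylamino on a saturated chain carbon bound to a carbonyl carbon), the same kind of change as that from compound 2 to compound 1, made at a place described in the same words. The step from compound 3 to compound 4 in this assay is expected to be a step that the limit leaves unreadable from compound 3 to compound 4. This expectation rests on the step that the two limits leave unreadable from compound 2 to compound 1, which did not move the reading off the limit (the limit of > 1000000 nM in this assay, at which 3 of the 3 values shown sit), and on the same limit holding for compound 3. Compound 4 is therefore estimated at 1500000 nM, with a range from 500000 nM to 5000000 nM, and the reading is most likely to come back once more as a limit rather than a number.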

Compound 4, half-maximal cytotoxic concentration: > 1000000 nM
Compound 4 gave a limit, no number; the forecaster's own chance of this, stated with the estimate: 85%; the middle value lies beyond the limit too.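

In this assay compound 3 and compound 4 both come back as limits, so no step can be read from the change of diethylamino to pyrrolidin-1-yl between them. All the compounds shown rest at the same reading: the limit of > 1000000 nM in this assay, at which 4 of the 4 values shown sit. What these compounds leave open is how far each lies from that limit, and whether either change would alter the reading at all.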